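Removing a methoxy group from a chalcone-like pyrazole

This account rests on a few compounds, and the source may have more. Where it says the series, first, only, none or still open, it means among the compounds named here.

Compound 1: `COc1cc(-c2cc(/C=C/C(=O)c3ccc(N)cc3)[nH]n2)cc(OC)c1OC`, 88%
Compound 2: `COc1cc(-c2cc(/C=C/C(=O)c3ccc(Cl)c(Cl)c3)[nH]n2)cc(OC)c1OC`, 89%

Both measured compounds were tested in a functional assay on HOP-92 cells (Homo sapiens) for cytotoxicity, read by sulforhodamine B assay, with a stated time of 48 h, tested at 0.01 uM; on this read-out higher numbers stand for a weaker effect at the one concentration tested and lower numbers for a stronger effect. Compound 1 gives 88%, and compound 2 gives 89%. Compound 1 stands as the lower of the two numbers, but the step of a number 1 percentage points higher from compound 1 to compound 2 (within the scatter) is within the scatter, so the two values cannot be told apart. That step exchanges the group on the carbonyl carbon and leaves the other end of the shared core untouched.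

Compound 3, `COc1ccc(-c2cc(/C=C/C(=O)c3ccc(N)cc3)[nH]n2)cc1OC`, differs from compound 1 at that other end: hydrogen in place of methoxy on an aromatic carbon. Within the data shown here, no measured step bears on this place. Among the measured compounds shown here, the one step available, a number 1 percentage points higher from compound 1 to compound 2 (within the scatter), concerns a different part of the molecule and was itself within the scatter, so it offers no direction. For the measured compounds named here, with both measured numbers at the weak end of the read-out and the only step flat, the expected step of a number 1 percentage points higher from compound 1 to compound 3 (within the scatter) is none beyond the scatter. Compound 3 is therefore estimated at 89%, with a range from 76% to 100%.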

Compound 3, a percentage reported as activity, at one concentration (the size of the read-out at that concentration, not a potency): 86%
Compound 3: middle estimate off by 3 percentage points, on the high side; low and high end bracket the measured number.
By their numbers in this assay, from the lowest: compounds 3, 1 and 2 (each within the scatter of the next).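

In this assay, replacing methoxy with hydrogen on this aromatic carbon gives a number 2 percentage points lower from compound 1 to compound 3 (within the scatter), so compound 3 cannot be told apart from compound 1 at this concentration. Among these compounds, this is the first reading at this end of the molecule, and it shows that the methoxy group at this place, ortho to a methoxy group and meta to a large group, can be exchanged for hydrogen with no change beyond the scatter, at least with 4-aminophenyl on the carbonyl carbon. No supporting data bear on why this exchange leaves the read-out within the scatter.

The compounds shown leave open whether a hydroxyl group, an ethoxy group or an amine on this aromatic carbon would give a number beyond the scatter, and whether the same exchange would read alike with 3,4-dichlorophenyl on the carbonyl carbon. They also leave open whether compound 1 and compound 3 would remain indistinguishable at higher concentrations, since a reading at a single concentration is not a measure of potency.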